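Nitro to Amino on the Chloro Sulfonamide

This account rests on a few compounds, and the source may have more. Where it says the series, first, only, none or still open, it means among the compounds named here.

compound 1 `O=[N+]([O-])c1ccc(S(=O)(=O)Nc2cccc3cc[nH]c23)cc1`: 15 ug/mL
compound 2 `O=[N+]([O-])c1ccc(S(=O)(=O)Nc2cccc3cc(Cl)[nH]c23)cc1`: 18 ug/mL
compound 3 `O=[N+]([O-])c1ccc(S(=O)(=O)Nc2cccc3c(Cl)c[nH]c23)cc1`: 14 ug/mL

In a functional assay on KB cells (Homo sapiens) for antiproliferative activity, read by colorimetric assay and MTT assay (a higher number here means a weaker inhibitor, a lower number a stronger inhibitor), compound 3 gives 14 ug/mL, level within the scatter with compound 1 and compound 2. Compound 4 `Nc1ccc(S(=O)(=O)Nc2cccc3c(Cl)c[nH]c23)cc1` differs from it by amino in place of nitro on an aromatic carbon, para to a large group (amino in place of nitro on an aromatic carbon). Among the compounds with values here, the only measured steps, a 1.2-fold higher number from compound 1 to compound 2 (0.08 log units; within the scatter) and a 1.1-fold lower number from compound 1 to compound 3 (0.03 log units; within the scatter), exchange hydrogen for chloro, and neither touches the nitro. Within the data shown here, no measured pair shows the new exchange, so the data set no size for it. The estimated change, held loosely, is a 2.3-fold lower number from compound 3 to compound 4 (0.37 log units; beyond the scatter). For compound 4 the expected value is 6 ug/mL, with an estimated range of 1 ug/mL to 25 ug/mL.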

Compound 4, half-maximal inhibitory concentration: 10 ug/mL
The estimate for compound 4 lay 1.7-fold (0.22 log units) below the measured number, and the stated range covers the measured number.
By their numbers in this assay, from the lowest: compounds 4, 3, 1 and 2 (each within the scatter of the next).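

Amino in place of nitro, on an aromatic carbon para to a large group, is the first exchange here that touches this end of the molecule, and in this assay it gives a 1.4-fold lower number from compound 3 to compound 4 (0.15 log units; within the scatter) and stays within the scatter. Compound 4 thus shows that the nitro can give way to amino with no step beyond the scatter. No measurement here offers a reason for this result.

Going by these compounds, whether an acetamide, a methoxy group or a carboxylic acid on this carbon would read differently remains open. So does whether the same exchange would give a similar step on compound 1 or compound 2.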